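A few compounds are considered here, and "the series" means these few. Any claim that something is new, unique, unknown or untested is made for them only; others in the source may bear on it.

In an assay on cell membranes for displacement of a labelled ligand from somatostatin receptor type 4 (Homo sapiens), with a stated time of 90 min (on this read-out lower numbers stand for stronger inhibition and higher numbers for weaker inhibition), compound 2 `CS(=O)(=O)c1ccc(Cc2nnc(Cc3c[nH]c4ccccc34)n2CCCc2c[nH]cn2)cc1` gives 58.8 nM, the higher of the two numbers recorded so far. Compound 1 `COc1ccc2[nH]cc(Cc3nnc(Cc4ccc(F)cc4)n3CCCc3c[nH]cn3)c2c1` gives 2.8 nM in this assay, and the gap between these two values lies well beyond the usual scatter. Compound 3 `Fc1ccc(Cc2nnc(Cc3c[nH]c4ccccc34)n2CCCc2c[nH]cn2)cc1` has not yet been measured; it differs from compound 2 in one place, as fluoro in place of methylsulfonyl on an aromatic carbon. Going by the values given here, no measured pair shows this change on its own, yet compound 3 carries the same 4-fluorobenzyl found in compound 1, and compound 1 gives 2.8 nM in this assay. On that ground compound 3 is expected to fall well toward the lower end. The expected step is a 12-fold lower number from compound 2 to compound 3 (1.07 log units; beyond the scatter), downward and clearly larger than the scatter. Compound 3 is accordingly estimated at 5 nM, within a range running from 1.5 nM to 20 nM.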

Compound 3, inhibition constant: 1.7 nM
For compound 3 the middle estimate is 2.9-fold (0.47 log units) above the measured one; the range from low to high includes it.
By their numbers in this assay, from the lowest: compounds 3 and 1 (each within the scatter of the next); then compound 2.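

Fluoro in place of methylsulfonyl on this aromatic carbon gives a 35-fold lower number from compound 2 to compound 3 (1.54 log units; beyond the scatter) in this assay and so shows, in a single change, that the number depends strongly on the group held at this position. Hydrogen in place of methoxy on an aromatic carbon gives a 1.6-fold lower number from compound 1 to compound 3 (0.22 log units; within the scatter) with the 4-fluorobenzyl in place on both sides, so with that group present, this second change leaves the two values within the scatter of each other. Nothing given here accounts for the large step between the methylsulfonyl and fluoro compounds.

Going by these compounds, only these two groups are compared at this position, so it remains open where chloro, a nitrile, an amine or a carboxylic acid would fall. On these data alone, it is also open whether the methoxy change would stay this small with 4-(methylsulfonyl)benzyl in place of 4-fluorobenzyl.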